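This account rests on a few compounds, and the source may have more. Where it says the series, first, only, none or still open, it means among the compounds named here.

Measured in a functional assay on NCI-H520 cells (Homo sapiens) for cytotoxicity; a higher number here means a weaker inhibitor of growth, a lower number a stronger inhibitor of growth:
- compound 1 `COc1ccc(C2=C(c3ccc(SC)cc3)CC3CCCN3C2=O)cc1OC(=O)CNC(=O)OC(C)(C)C`: 7000 nM
- compound 2 `COc1ccc(C2=C(c3ccc(SC)cc3)CC3CCCN3C2=O)cc1C`: 100 nM
- compound 3 `CSc1ccc(C2=C(c3ccc(F)c(F)c3)C(=O)N3CCCC3C2)cc1`: 200 nM

Compound 3, at 200 nM, lies within the usual scatter of compound 2, at 100 nM, while compound 1 shows a much higher number, 7000 nM.

The next compound is compound 4 `CSc1ccc(C2=C(c3ccc(O)c(O)c3)C(=O)N3CCCC3C2)cc1`. It carries 3,4-dihydroxyphenyl in place of 3,4-difluorophenyl on a double-bonded ring carbon, next to the ring atom that bears a 4-(methylsulfanyl)phenyl group (3,4-dihydroxyphenyl in place of 3,4-difluorophenyl on a double-bonded ring carbon). The group that enters has hydrogen-bond donors, and the group that leaves has none.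

Going by the values given here, two measured steps bear on this. The closer one changes the same position: a 2.0-fold higher number from compound 2 to compound 3 (0.30 log units; within the scatter). Swapping one substituted phenyl for another at this spot therefore made no difference beyond the scatter. The other step, a 70-fold lower number from compound 1 to compound 2 (1.85 log units; beyond the scatter), is large, but it replaces a long chain on an aromatic carbon, a much bigger change than this one. Among the compounds with values here, no measured compound has 3,4-dihydroxyphenyl, so a modest rise in this assay is expected, with real uncertainty in either direction.

The expected change is a 1.5-fold higher number from compound 3 to compound 4 (0.18 log units; within the scatter). For compound 4 the estimated value is 300 nM, with an expected range of 80 nM to 1500 nM.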

Compound 4, concentration for 50% growth inhibition: 60000 nM
Estimate against measurement, compound 4: 200-fold (2.30 log units) below; measured number above the stated range.
By their numbers in this assay, from the lowest: compounds 2 and 3 (each within the scatter of the next); then compound 1; then compound 4.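

In this assay, this position turns out to be far from indifferent to which substituted phenyl it carries: putting 3,4-dihydroxyphenyl in place of 3,4-difluorophenyl gives a 300-fold higher number from compound 3 to compound 4 (2.48 log units; beyond the scatter) and putting it in place of 4-methoxy-3-methylphenyl gives a 600-fold higher number from compound 2 to compound 4 (2.78 log units; beyond the scatter) on the same core. The earlier swap at this spot stayed within the scatter, so that step had hidden how much the outcome can depend on the group chosen, and the group that now enters differs from 3,4-difluorophenyl in having oxygen in place of fluorine and in carrying hydrogen-bond donors where the other has none. Nothing available here explains why this exchange weakens growth inhibition so strongly.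

The compounds shown leave open whether both hydroxyl groups are tied to this loss, since neither a phenyl with a single hydroxyl nor 3,4-dimethoxyphenyl, with methyl groups on both oxygens, stands among them. They also leave open whether an aminophenyl group at this position would behave like the 3,4-dihydroxyphenyl group or like the 3,4-difluorophenyl group.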